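Methoxy to nitro exchange repeated on a second core

The source may hold more compounds than are shown below. What is called first, only, known or untested is meant among the compounds shown, and "the series" means these compounds.

Compound 1 `C#CCOc1ccc(/C=C/C(=O)c2ccc(OC)cc2)cc1` is measured in a functional assay on MCF7 cells (Homo sapiens) for inhibition, read by MTT assay, with a stated time of 48 h, tested at 10 uM (a higher number here means more inhibition of growth at the concentration tested, a lower number less inhibition of growth), and gives 32%. Compound 2 `C#CCOc1ccc(/C=C/C(=O)c2ccc([N+](=O)[O-])cc2)cc1` carries the change (nitro in place of methoxy on an aromatic carbon); in this assay compound 2 gives 44%. The resulting step is a number 12 percentage points higher from compound 1 to compound 2 (beyond the scatter). Compound 3 `COc1ccc(C(=O)/C=C/c2ccc(OCc3cn(Cc4ccccc4)nn3)cc2)cc1` rests on a different core; the difference between the core of compound 1 and the core of compound 3 is not broken down here. In this assay compound 3 gives 70%, the highest of the three numbers, beyond the scatter from both compound 2 and compound 1.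

Compound 4 `O=C(/C=C/c1ccc(OCc2cn(Cc3ccccc3)nn2)cc1)c1ccc([N+](=O)[O-])cc1` is not yet measured. It differs from compound 3 by nitro in place of methoxy on an aromatic carbon, the same change at the same place as that from compound 1 to compound 2; it occurs twice among these four compounds. Among the measured compounds shown here, only one measured instance exists, and it sits on a different core, so carrying it over is uncertain. Compound 4 is expected to show a step of a number 9 percentage points higher from compound 3 to compound 4 (within the scatter) in this assay, near the size of a number 12 percentage points higher from compound 1 to compound 2 (beyond the scatter), with limited room above compound 3. Compound 4 is estimated at 79%, between 64% and 92%.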

Compound 4, percent growth inhibition at one concentration: "not active" (no number reported)
Compound 4: no number reported; no gap can be computed for the estimate.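

Compound 4 is reported only as not active, without a number, and the step from compound 3 to compound 4 in this assay cannot be read. No supporting data bear on this result. The compounds shown leave open whether nitro in place of methoxy acts alike on the two cores.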